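The compounds below may be only part of what the source reports. "The series", "measured", "known", "first", "only" and "open" are said of these compounds alone.

Measured compounds in an assay on isolated protein for inhibition of Amine oxidase [flavin-containing] A (Homo sapiens), read by fluorescence, with stated times of 15 min and 20 min; a higher number here means a weaker inhibitor, a lower number a stronger inhibitor:
- compound 1, `CC(C)(C)c1cc(C(=O)NCCC2CCN(Cc3ccccc3)CC2)cc(C(C)(C)C)c1O`: 109000 nM
- compound 2, `CC(C)(C)c1cc(/C=C/C(=O)NCCC2CCN(Cc3ccccc3)CC2)cc(C(C)(C)C)c1O`: 62300 nM

Two compounds measured, neither a strong inhibitor. In this assay, within the data shown here, compound 2 gives the lower of the two numbers, yet the value of compound 1 lies within the scatter of it, so the two cannot be ranked; the two share everything apart from the linker, where compound 2 carries a double bond that compound 1 lacks, and no step between them is counted here.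

Compound 3, `COc1ccc(CN2CCC(CCNC(=O)/C=C/c3cc(C(C)(C)C)c(O)c(C(C)(C)C)c3)CC2)cc1`, is not yet measured. It differs from compound 2 in one place: methoxy in place of hydrogen on an aromatic carbon. The difference is small in size and sits on the benzyl end of the molecule, far from the hindered phenol and the amide. Among the measured compounds shown here, no measured pair shows what this kind of change does, so the expectation can rest only on the weak values of compound 1 and compound 2 and on the smallness of the added group. The step from compound 2 to compound 3 is expected to be small, with no clear direction, and most likely within the scatter; the expected step is a 1.0-fold lower number from compound 2 to compound 3 (0.02 log units; within the scatter). Compound 3 is expected to give 60000 nM, within a range from 25000 nM to 150000 nM.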

Compound 3, half-maximal inhibitory concentration: 72500 nM
The estimate for compound 3 lay 1.2-fold (0.08 log units) below the measured number; measured number inside the range.
By their numbers in this assay, from the lowest: compounds 2, 3 and 1 (each within the scatter of the next).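

In this assay, going from benzyl to 4-methoxybenzyl gives a 1.2-fold higher number from compound 2 to compound 3 (0.07 log units; within the scatter), so compound 2 and compound 3 cannot be ranked. Among these compounds, this pair gives the series its only reading at the benzyl end: methoxy in place of hydrogen, on an aromatic carbon para to a large group, leaves the number within the scatter, though this single pair says nothing about other groups at this position or about this group elsewhere on the ring. No supporting measurement bears on this result.

As far as these compounds go, it remains open whether a hydroxyl group, a chlorine atom or an amine at the same position would move the number beyond the scatter, and whether methoxy on the shorter linker of compound 1 would behave as it does on the linker of compound 2. From the compounds shown here alone, the hindered phenol and the amide are the same in compound 1, compound 2 and compound 3, so it is also open what a methyl ether in place of the phenol hydroxyl, or a longer chain between the amide and the piperidine-bearing end, would do to these numbers.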